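Fluorophenyl Amide Expected to Remain Beyond the Limit

The compounds below may be only part of what the source reports. "The series", "measured", "known", "first", "only" and "open" are said of these compounds alone.

Compound 1 `O=C(Nc1ccccc1)c1cccc(/C=C2\CC(=O)N(c3ccccc3)C2=O)c1` gives in an ADME assay on SW480 cells (Homo sapiens) for cytotoxicity, read by MTT assay, with a stated time of 72 h (on this read-out higher numbers stand for weaker inhibition and lower numbers for stronger inhibition), only a limit, > 100000 nM.
Compound 2 `O=C(NCc1ccccc1)c1cccc(/C=C2\CC(=O)N(c3ccccc3)C2=O)c1` gives in this assay only a limit, > 100000 nM.

Compound 2 thus stands at the limit, as does every value shown (the limit of > 100000 nM in this assay, at which 2 of the 2 values shown sit). Within the data shown here, the one measured step, a step that the two limits leave unreadable from compound 1 to compound 2, is unreadable. Compound 3 `O=C(Nc1cccc(F)c1)c1cccc(/C=C2\CC(=O)N(c3ccccc3)C2=O)c1` differs by 3-fluorophenyl in place of benzyl on an amide-type nitrogen. No readable step bears on this change, so no shift beyond the scatter is expected; the step that the limit leaves unreadable from compound 2 to compound 3 is estimated as none. Compound 3 is expected at 150000 nM, with a range of 50000 nM to 500000 nM, most likely again as a limit.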

Compound 3, half-maximal inhibitory concentration: > 100000 nM
Compound 3 was reported as a limit (the forecaster's own chance of this, stated with the estimate: 85%); the middle value does not contradict the limit.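

Among these compounds, compound 1, compound 2 and compound 3 all give only limits in this assay, so no step among them can be read. The compounds shown leave open whether any group on the amide-type nitrogen would yield a measurable value.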